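The source may hold more compounds than are shown below. What is called first, only, known or untested is meant among the compounds shown, and "the series" means these compounds.

Measured so far in a functional assay on HeLa cells (Homo sapiens) for antiproliferative activity, read by MTT assay, with a stated time of 48 h; on this read-out higher numbers stand for weaker inhibition and lower numbers for stronger inhibition:

- compound 1 `O=[N+]([O-])c1cccc(CSc2nnc(-c3ccc4c(c3)OCCO4)o2)c1`: 35600 nM
- compound 2 `Clc1ccccc1CSc1nnc(-c2ccc3c(c2)OCCO3)o1`: 36800 nM
- compound 3 `Fc1ccccc1CSc1nnc(-c2ccc3c(c2)OCCO3)o1`: 41600 nM

The three compounds share one core and differ only in the group on the benzyl ring. Their numbers sit close together: compound 1 is within the scatter of compound 2 and of compound 3, so none of the three can be called stronger or weaker than another on this read-out. Going by the values given here, the only single-point step among them, a 1.1-fold higher number from compound 2 to compound 3 (0.05 log units; within the scatter), also stays within the scatter.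

Compound 4 `c1ccc(CSc2nnc(-c3ccc4c(c3)OCCO4)o2)cc1` carries no group on that ring at all. Compared with compound 1 the change is hydrogen in place of nitro on an aromatic carbon. Among the compounds with values here, no measured step removes a substituent; the one step seen, chloro to fluoro, swaps one halogen for another and says little about losing the nitro group. All that the three numbers show is that this position has tolerated three different groups without any step beyond the scatter, so little movement is expected in this assay.

Compound 4 is therefore estimated at 38000 nM, with a range from 18000 nM to 80000 nM, a step of a 1.1-fold higher number from compound 1 to compound 4 (0.03 log units; within the scatter) expected to stay within the scatter.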

Compound 4, half-maximal inhibitory concentration: 40300 nM
Compound 4: the middle estimate sits 1.1-fold (0.03 log units) below what was measured; the measured number falls inside the stated range.
By their numbers in this assay, from the lowest: compounds 1, 2, 4 and 3 (each within the scatter of the next).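

Going by these compounds alone, compound 4 shows for the first time what happens when the ring carries no group at all, and in this assay the loss barely registers: taking away the nitro group gives a 1.1-fold higher number from compound 1 to compound 4 (0.05 log units; within the scatter) and taking away the fluoro gives a 1.0-fold lower number from compound 3 to compound 4 (0.01 log units; within the scatter) while taking away the chloro gives a 1.1-fold higher number from compound 2 to compound 4 (0.04 log units; within the scatter). The bare ring therefore stands level with all three substituted rings, so none of these groups is shown to be needed for the number seen on this read-out. No separate measurement bears on why the numbers stay so close together.

An amine, a carboxylic acid or a longer chain on that ring might still shift the number, since only small groups appear here. On these data alone, whether changes to the shared core itself matter more also remains open.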